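Trimethoxyphenyl-pyrimidine series: expectation for compound 4

The source may hold more compounds than are shown below. What is called first, only, known or untested is meant among the compounds shown, and "the series" means these compounds.

Compound 1 `COc1cc(-c2cc(-c3ccccc3)nc(-c3ccccc3)n2)cc(OC)c1OC` is the reference point. Among the compounds with values here, in a functional assay on HCT-116 cells (Homo sapiens) for inhibition, read by MTT assay, with a stated time of 48 h (a lower number here means a stronger inhibitor, a higher number a weaker inhibitor), compound 1 gives 9950 nM, the second highest of the three numbers so far. Compound 2 `COc1cc(-c2cc(-c3cccc(O)c3)nc(-c3ccccc3)n2)cc(OC)c1OC` gives 20400 nM and compound 3 `COc1cc(-c2cc(-c3ccc(O)cc3O)nc(-c3ccccc3)n2)cc(OC)c1OC` gives 5890 nM; compound 3 is the nearest neighbour of compound 1 and compound 2 the furthest.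

Three single-point steps connect the measured compounds. a 2.1-fold higher number from compound 1 to compound 2 (0.31 log units; beyond the scatter); a 1.7-fold lower number from compound 1 to compound 3 (0.23 log units; within the scatter); a 3.5-fold lower number from compound 2 to compound 3 (0.54 log units; beyond the scatter). Taken together, these steps are all modest, and the one that moves the number down stays within the scatter.

Compound 4 `COc1ccc(-c2cc(-c3cc(OC)c(OC)c(OC)c3)nc(-c3ccccc3)n2)c(OC)c1` differs from compound 1 in one place: 2,4-dimethoxyphenyl in place of phenyl on an aromatic carbon. Within the data shown here, the step that bears most on this is the one from compound 1 to compound 3, which put hydroxy groups at the same two ring positions and gave a 1.7-fold lower number from compound 1 to compound 3 (0.23 log units; within the scatter). Here the groups entering carry no hydrogen-bond donors, so that step is a guide only by analogy; the series holds no methoxy-for-hydrogen step at all. A change of roughly the size seen for compound 3, or none beyond the scatter, is therefore expected, with the direction uncertain.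

On that basis compound 4 is estimated at 7500 nM, within a range of 3000 nM to 19000 nM, which corresponds to an expected step of a 1.3-fold lower number from compound 1 to compound 4 (0.12 log units; within the scatter).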

Compound 4, half-maximal inhibitory concentration: > 25000 nM
Compound 4 ended at the assay's limit (the forecaster's own chance of this, stated with the estimate: 5%); middle value at least 3.3-fold (0.52 log units) from the limit.
By their numbers in this assay, from the lowest: compounds 3 and 1 (each within the scatter of the next); then compound 2. At a limit, above all of these: compound 4.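

Compound 4 gives no number in this assay, only a limit, so every step to it is a floor set by that limit: the limit of > 25000 nM in this assay, at which 1 of the 4 values shown sits.

Even as floors, two of these steps lie beyond the scatter: an at least 2.5-fold higher number from compound 1 to compound 4 (0.40 log units; beyond the scatter), and an at least 4.2-fold higher number from compound 3 to compound 4 (0.62 log units; beyond the scatter). This position therefore does not tolerate every substituted phenyl alike, since 2,4-dihydroxyphenyl stayed within the scatter of phenyl, whereas 2,4-dimethoxyphenyl, with its groups on the same two ring positions, moved the number up; in these compounds the identity of the groups matters, not only where they sit on the ring. The remaining step, an at least 1.2-fold higher number from compound 2 to compound 4 (0.08 log units; that floor lies within the scatter), cannot be read, so compound 4 and compound 2 cannot be ordered.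

On these data alone, it remains open whether one methoxy group alone is enough for this rise or whether both are needed, and how far the true value of compound 4 lies past the limit. Also open, as far as these compounds go, is where an amine or a carboxylic acid at the same two ring positions would fall relative to the hydroxy and methoxy groups.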